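Two substitutions and a TYRO3 binding limit

This account rests on a few compounds, and the source may have more. Where it says the series, first, only, none or still open, it means among the compounds named here.

Compound 1 `CCN1CCN(c2ccc(-c3nn(Cc4cn(Cc5ccccc5)nn4)c4nc(NC)ncc34)cn2)CC1` — 1900 nM
Compound 2 `CNc1ncc2c(-c3ccc(N4CCN(C(=O)C(C)(C)C)CC4)nc3)nn(Cc3cn(Cc4ccccc4)nn3)c2n1` — limit only, > 10000 nM
Compound 3 `CCN1CCN(c2ccc(-c3nn(CC4CCCC4)c4nc(NC)ncc34)cn2)CC1` — limit only, > 10000 nM

In an assay for inhibition of tyrosine-protein kinase receptor TYRO3 (Homo sapiens), read by 33P incorporation, in the presence of a further agent that is not named here (on this read-out higher numbers stand for weaker inhibition and lower numbers for stronger inhibition), compound 1 gives 1900 nM. Compound 2 reaches only a limit of the assay, > 10000 nM. Compound 3 likewise reaches only a limit, > 10000 nM. The change from compound 1 to compound 2 is (tert-butyl)carbonyl in place of ethyl on an amine nitrogen in a ring, and it brings an at least 5.2-fold higher number from compound 1 to compound 2 (0.72 log units; beyond the scatter). The two cores differ by cyclopentyl in place of 1-benzyl-1H-1,2,3-triazol-4-yl on a saturated chain carbon bound to an aromatic nitrogen, and that change brings an at least 5.2-fold higher number from compound 1 to compound 3 (0.72 log units; beyond the scatter); both steps end at the limit of > 10000 nM in this assay, at which 2 of the 3 values shown sit. Compound 4 `CNc1ncc2c(-c3ccc(N4CCN(C(=O)C(C)(C)C)CC4)nc3)nn(CC3CCCC3)c2n1` has not been measured. It differs from compound 3 by (tert-butyl)carbonyl in place of ethyl on an amine nitrogen in a ring, the same change as that from compound 1 to compound 2, at a place described in the same words. For compound 4 the expected step is a step that the limit leaves unreadable from compound 3 to compound 4. This expectation rests on an at least 5.2-fold higher number from compound 1 to compound 2 (0.72 log units; beyond the scatter). Compound 3 already sits at a limit, > 10000 nM. Compound 4 is therefore estimated at 30000 nM, most likely reported again only as a limit.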

Compound 4, half-maximal inhibitory concentration: > 10000 nM
Compound 4: a limit, no number (the forecaster's own chance of this, stated with the estimate: 95%); the middle value lies beyond the limit too.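

Compound 4 also reaches only a limit, > 10000 nM. No step from compound 2 or compound 3 to compound 4 can be read: the limit of > 10000 nM in this assay, at which 3 of the 4 values shown sit.

From the compounds shown here alone, how compound 2, compound 3 and compound 4 rank among themselves in this assay stays open.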